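The compounds below may be only part of what the source reports. "The series", "measured", "known", "first", "only" and "open" are said of these compounds alone.

Measured compounds:

Compound 1, `FC(F)(F)c1cccc(/C=C\c2cc3ccccc3nc2Cl)c1`, gives 3750 nM in a functional assay on MDA-MB-231 cells (Homo sapiens) for antiproliferative activity, read by sulforhodamine B assay, with a stated time of 72 h; a lower number here means a stronger inhibitor, a higher number a weaker inhibitor.
Compound 2, `COc1ccc2nc(Cl)c(/C=C\c3cccc(C(F)(F)F)c3)cc2c1`, gives 3280 nM in this assay.
Compound 3, `FC(F)(F)c1ccc(/C=C\c2cc3ccccc3nc2Cl)c(C(F)(F)F)c1`, gives 41800 nM in this assay.

The step from compound 1 to compound 2 is methoxy in place of hydrogen on an aromatic carbon; it produced a 1.1-fold lower number from compound 1 to compound 2 (0.06 log units; within the scatter). Compound 3 stands apart: its number is the highest of the three, and its gap to compound 1 and to compound 2 lies beyond the scatter. The difference between the core of compound 3 and the core of compound 1 is not broken down here.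

Compound 4, `COc1ccc2nc(Cl)c(/C=C\c3ccc(C(F)(F)F)cc3C(F)(F)F)cc2c1`, has not yet been measured. It differs from compound 3 by methoxy in place of hydrogen on an aromatic carbon, the same kind of change that was made from compound 1 to compound 2; the place lines of the two changes read the same, so they describe the same kind of site. Because the earlier step was a 1.1-fold lower number from compound 1 to compound 2 (0.06 log units; within the scatter), a step of similar small size is expected here, and for compound 4 an expected step of a 1.1-fold lower number from compound 3 to compound 4 (0.04 log units; within the scatter) from compound 3 is foreseen. Compound 4 is therefore estimated at 38000 nM, with the likely range running from 15000 nM to 100000 nM.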

Compound 4, half-maximal inhibitory concentration: > 50000 nM
Compound 4 gave a limit, no number (the forecaster's own chance of this, stated with the estimate: 10%); middle value at least 1.3-fold (0.11 log units) from the limit.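

In this assay compound 4 gives > 50000 nM, which is a limit of the assay and not a number. On these data alone, the change of hydrogen to methoxy on the core of compound 3 is thus known only as an at least 1.1-fold higher number from compound 3 to compound 4 (0.07 log units; that floor lies within the scatter); this shows that methoxy brought no lower number on that core, while the true size of the step stays unknown. Whether the change carries over from one core to the other with the same size is shown neither way: the same change on two cores in this assay, a 1.1-fold lower number (0.06 log units; within the scatter) from compound 1 to compound 2 and an at least 1.1-fold higher number (0.07 log units; that floor lies within the scatter) from compound 3 to compound 4; the limit leaves it open whether they differ.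

The compounds shown leave open how other groups on this aromatic carbon, such as an amine, a hydroxyl or a carboxylic acid, would read on either core. They also leave open how an alkoxy group with a longer chain, such as ethoxy, would compare with methoxy in this assay.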